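Carboxylic Acid on the Amide Ring of Compound 2

The source may report more compounds than this note shows. Statements on the series, on what has been measured and on what is new or still open speak of the compounds shown alone.

Compound 1 `N=C(N)c1cccc(OCC(=O)Nc2ccc(C(=O)N3CCC3)cc2)c1` gives 2050 nM in an assay on isolated protein for inhibition of serine protease 1 (Homo sapiens); a lower number here means a stronger inhibitor, a higher number a weaker inhibitor. Among the compounds with values here, compound 2 `N=C(N)c1cccc(OCC(=O)Nc2ccc(C(=O)N3CC=CC3)cc2)c1` gives 875 nM in this assay, the lowest of the two numbers measured so far; the single measured step, a 2.3-fold lower number from compound 1 to compound 2 (0.37 log units; beyond the scatter), lies beyond the usual scatter. Compound 3 `N=C(N)c1cccc(OCC(=O)Nc2ccc(C(=O)N3CCCC3C(=O)O)cc2)c1` differs from compound 2 by a group of 8 heavy atoms (5 carbon, 1 nitrogen, 2 oxygen; one five-membered non-aromatic ring with 1 hetero atom) in place of a group of 5 heavy atoms (4 carbon, 1 nitrogen; one five-membered non-aromatic ring with 1 hetero atom), on a carbonyl carbon. Within the data shown here, the step from compound 1 to compound 2 bears on this only loosely, as it exchanged one ring on the carbonyl carbon for another without bringing in a donor or acceptor; no measured step shows what a carboxylic acid on that ring does here. The expectation for compound 3 is therefore a step of uncertain direction, a 1.4-fold higher number from compound 2 to compound 3 (0.14 log units; within the scatter), with wide bounds. Compound 3 is estimated at 1200 nM in this assay, within a range from 300 nM to 5000 nM.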

Compound 3, half-maximal inhibitory concentration: > 10000 nM
Compound 3: only a limit was reported (the forecaster's own chance of this, stated with the estimate: 5%); middle value at least 8.3-fold (0.92 log units) from the limit.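

On this carbonyl carbon, 2-carboxypyrrolidin-1-yl is the first group shown that carries a hydrogen-bond donor and acceptor, and it brings the first large change in this assay: an at least 11-fold higher number from compound 2 to compound 3 (1.05 log units; beyond the scatter). Set against azetidin-1-yl, the same group gives an at least 4.8-fold higher number from compound 1 to compound 3 (0.68 log units; beyond the scatter), so a five-membered ring here does not by itself secure the lower number seen with compound 2. Compound 3 reached only a limit of the assay, so the full size of both steps stays unknown: the limit of > 10000 nM in this assay, at which 1 of the 3 values shown sits.

Still open, from the compounds shown here alone, is whether the carboxylic acid alone accounts for the change, or whether the different ring contributes, a question a plain pyrrolidin-1-yl group would address. Also open, going by these compounds, is how a methyl ester or a primary amide would behave in place of the carboxylic acid.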